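This account rests on a few compounds, and the source may have more. Where it says the series, first, only, none or still open, it means among the compounds named here.

Measured in an assay on T-REx-293 cells for inhibition of potassium channel subfamily T member 1 (Homo sapiens), read by patch clamp; a higher number here means a weaker inhibitor, a lower number a stronger inhibitor:
compound 1 `C[C@@H](c1nc(-c2cccc(F)c2)no1)N(C)C(=O)c1cc(C(F)(F)F)nn1C`: 6490 nM
compound 2 `C[C@H](NS(=O)(=O)c1cc(C(F)(F)F)nn1C)c1nc(-c2cccc(F)c2)no1`: > 30000 nM, a limit of the assay, not a number
compound 3 `Cc1cncc(-c2noc([C@H](C)NC(=O)c3cc(C(F)(F)F)nn3C)n2)c1`: 1370 nM

Compound 3 holds the lower of the two numbers here; its nearest neighbour, compound 1, stands beyond the scatter above it. Compound 2 gives only (the limit of > 30000 nM in this assay, at which 1 of the 3 values shown sits). Compound 4 `C[C@H](NC(=O)c1cc(C(F)(F)F)nn1C)c1nc(-c2ccnc(C(F)(F)F)c2)no1` has not yet been measured in this assay. It differs from compound 3 in one place: 2-(trifluoromethyl)pyridin-4-yl in place of 5-methylpyridin-3-yl on an aromatic carbon. Among the measured compounds shown here, no measured pair shows this swap, so the direction is open. The step of a 1.5-fold higher number from compound 3 to compound 4 (0.16 log units; within the scatter) is expected to be small, most likely within the scatter, with a slight lean toward a weaker inhibitor. Compound 4 is therefore estimated at 2000 nM, between 600 nM and 7000 nM.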

Compound 4, half-maximal inhibitory concentration: 40 nM
Beside the measured number, compound 4's estimate is 50-fold (1.70 log units) above it, outside the stated range (below it).
By their numbers in this assay, from the lowest: compound 4; then compound 3; then compound 1. At a limit, above all of these: compound 2.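

Among the compounds shown here, the change from 5-methylpyridin-3-yl to 2-(trifluoromethyl)pyridin-4-yl gives a 34-fold lower number from compound 3 to compound 4 (1.53 log units; beyond the scatter) in this assay and so marks this aromatic carbon, between two ring nitrogen atoms, as a place where the choice of pyridine group can move the number strongly, which no earlier pair could show. Nothing measured here accounts for the size of this step.

The compounds shown leave open whether the trifluoromethyl group or the changed ring attachment carries the step, as both change at once. Also open, as far as these compounds go, is how a plain pyridin-4-yl, or a nitrile in place of the trifluoromethyl, would read.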